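A few compounds are considered here, and "the series" means these few. Any claim that something is new, unique, unknown or untested is made for them only; others in the source may bear on it.

Measured so far:
Compound 1 `O=C(Nc1cc(C(F)(F)F)cc(C(F)(F)F)c1)c1ccccc1O` in an assay for inhibition of transmembrane protease serine 4 (Homo sapiens), read by fluorescence (a higher number here means a weaker inhibitor, a lower number a stronger inhibitor), gives > 100000 nM, which is a limit of the assay rather than a number.
Compound 2 `O=C(Nc1cc(C(F)(F)F)cc(C(F)(F)F)c1)c1cccc(Cl)c1O` in this assay gives 12000 nM.

For the measured compounds named here, compound 2 holds the only actual number in this assay; the one other value is a limit. Going by the values given here, the single measured step, an at least 8.3-fold lower number from compound 1 to compound 2 (0.92 log units; beyond the scatter), is read against (the limit of > 100000 nM in this assay, at which 1 of the 2 values shown sits), so its true size could be larger than the stated floor.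

Compound 3 `O=C(Nc1cc(C(F)(F)F)cc(C(F)(F)F)c1)c1cc(Cl)cnc1O` differs from compound 2 by 5-chloro-2-hydroxypyridin-3-yl in place of 3-chloro-2-hydroxyphenyl on a carbonyl carbon. Both rings keep a chlorine and a hydroxyl, but the ring itself now contains a nitrogen. Among the compounds with values here, no measured step swaps a ring carbon for a nitrogen or shifts the chlorine, so the step from compound 1 to compound 2 offers no direct guide; it only shows that changes on this ring can move the number well beyond the scatter. The expectation is therefore a step of uncertain direction, most likely modest and with wide uncertainty.

Compound 3 is expected to give about 15000 nM, within a range of 3000 nM to 70000 nM, in this assay. This estimate implies a step of a 1.3-fold higher number from compound 2 to compound 3 (0.10 log units; within the scatter), expected rather than measured.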

Compound 3, half-maximal inhibitory concentration: > 100000 nM
Compound 3: no number, only a limit; the forecaster's own chance of this, stated with the estimate: 25%; at least 6.6-fold (0.82 log units) between middle value and limit.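

In this assay, keeping a chlorine and a hydroxyl on the ring is not enough to hold the measured number: putting 5-chloro-2-hydroxypyridin-3-yl in place of 3-chloro-2-hydroxyphenyl on the carbonyl carbon gives an at least 8.3-fold higher number from compound 2 to compound 3 (0.92 log units; beyond the scatter). For the compounds shown here, this shows that the effect of chlorine seen earlier does not carry over to every chlorinated ring at this place, and compound 2, at 12000 nM, remains the only compound here with an actual number rather than a limit. The step between the other two compounds cannot be read, because both values are limits: the limit of > 100000 nM in this assay, at which 2 of the 3 values shown sit.

The ring nitrogen and the shifted chlorine arrive together in compound 3, so the compounds shown do not tell which of the two changes matters, or whether it takes both. Also open, from the compounds shown here alone, is how a bromine, a methyl group or a nitrile in place of the chlorine of 3-chloro-2-hydroxyphenyl would read, and whether any such group would give a lower number than compound 2 does.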